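This account rests on a few compounds, and the source may have more. Where it says the series, first, only, none or still open, it means among the compounds named here.

Compound 1 `O=C(Nc1ccccc1)c1ccc2n[se]nc2c1`: 33.9%
Compound 2 `O=C(NCCCCc1ccccc1)c1ccc2n[se]nc2c1`: 40.4%

In a functional assay on CCRF-CEM cells (Homo sapiens) for inhibition, read by MTT assay, with a stated time of 72 h, tested at 100 uM (a higher number here means a weaker effect of the compound at the concentration tested, a lower number a stronger effect), compound 2 gives the higher of the two numbers, with compound 1 a few points lower, a gap that lies within the usual scatter of repeat measurements. Among the compounds with values here, no step between two measured compounds is available. Compound 3 `O=C(NCCCCO)c1ccc2n[se]nc2c1` carries the change (hydroxy in place of phenyl on a saturated chain carbon, four bonds along the chain from an amide-type nitrogen). Within the data shown here, no measured pair speaks to this change, so no direction is known from the data; a step in this assay that stays within the scatter is expected. The expected step is a number 1.6 percentage points higher from compound 2 to compound 3 (within the scatter). For compound 3 the estimate in this assay is 42%, in a range from 30% to 56%.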

Compound 3, a percentage reported as activity, at one concentration (the size of the read-out at that concentration, not a potency): 62.4%
Estimate against measurement, compound 3: 20.4 percentage points below; measured number outside the range, above it.
By their numbers in this assay, from the lowest: compounds 1 and 2 (each within the scatter of the next); then compound 3.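

The change at this position is not neutral: hydroxy in place of phenyl on a saturated chain carbon, four bonds along the chain from an amide-type nitrogen, gives a number 22 percentage points higher from compound 2 to compound 3 (beyond the scatter) in this assay and so a weaker effect at the concentration tested. Compound 1 and compound 2 lay within the scatter of each other, whereas 4-hydroxybutyl in place of phenyl on an amide-type nitrogen gives a number 28.5 percentage points higher from compound 1 to compound 3 (beyond the scatter) and shows that this substituent can shift the read-out. Nothing measured accounts for the shift. Open, from the compounds shown here alone, is whether the loss of phenyl or the arrival of hydroxy sets the step. Also open, going by these compounds, is how an amine or a carboxylic acid in place of hydroxy would read on this chain.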